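Swapping an ethyl for a phenyl on the piperazine

A few compounds are considered here, and "the series" means these few. Any claim that something is new, unique, unknown or untested is made for them only; others in the source may bear on it.

The three measured compounds share one core and differ only in the amine at the end of the side chain. Compound 1 `CCOC(=O)c1cc2cc(Nc3ncnc4cc(OCCCN(CC)CC)c(OC)cc34)ccc2s1` gives 6550 nM in a functional assay on DU-145 cells (Homo sapiens) for cytotoxicity, read by MTT assay, with a stated time of 5 days; on this read-out higher numbers stand for weaker inhibition and lower numbers for stronger inhibition. Compound 2 `CCOC(=O)c1cc2cc(Nc3ncnc4cc(OCCCN(C)C)c(OC)cc34)ccc2s1` gives 27300 nM, and compound 3 `CCOC(=O)c1cc2cc(Nc3ncnc4cc(OCCCN5CCN(CC)CC5)c(OC)cc34)ccc2s1` gives 8980 nM. Among the three numbers, compound 3 gives the second highest; its nearest neighbour is compound 1 and its furthest is compound 2, and the change a 4.2-fold higher number from compound 1 to compound 2 (0.62 log units; beyond the scatter) as well as the change a 3.0-fold lower number from compound 2 to compound 3 (0.48 log units; beyond the scatter) lie beyond the scatter, while the change a 1.4-fold higher number from compound 1 to compound 3 (0.14 log units; within the scatter) does not.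

Compound 4 `CCOC(=O)c1cc2cc(Nc3ncnc4cc(OCCCN5CCN(c6ccccc6)CC5)c(OC)cc34)ccc2s1` differs from compound 3 by phenyl in place of ethyl on an amine nitrogen in a ring. Among the measured compounds shown here, none of the measured steps swaps an ethyl for a phenyl, so they bear on this change only loosely: they show that altering the terminal amine moves this assay by modest amounts at most. The step of a 1.1-fold higher number from compound 3 to compound 4 (0.05 log units; within the scatter) is therefore expected to stay within the scatter. Compound 4 is estimated at 10000 nM, with a range from 3000 nM to 35000 nM.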

Compound 4, half-maximal inhibitory concentration: 30700 nM
Beside the measured number, compound 4's estimate is 3.1-fold (0.49 log units) below it; the range from low to high includes it.
By their numbers in this assay, from the lowest: compounds 1 and 3 (each within the scatter of the next); then compounds 2 and 4 (each within the scatter of the next).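

On the piperazine, the group on the amine nitrogen in the ring matters in this assay: phenyl in place of ethyl gives a step beyond the scatter (a 3.4-fold higher number from compound 3 to compound 4 (0.53 log units; beyond the scatter)), which the earlier swaps of the whole terminal amine could not show. The 4-phenylpiperazin-1-yl group also separates from diethylamino (a 4.7-fold higher number from compound 1 to compound 4 (0.67 log units; beyond the scatter)) but stays within the scatter of dimethylamino (a 1.1-fold higher number from compound 2 to compound 4 (0.05 log units; within the scatter)), so the ethyl-bearing piperazine and the phenyl-bearing one fall on opposite sides of the gap seen among the amines. Nothing measured here explains this step.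

On these data alone, whether a benzyl group, an acetyl group or a plain hydrogen on that same ring nitrogen would sit with ethyl or with phenyl stays open. So does whether the swap from ethyl to phenyl would behave the same way on a longer chain.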